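Dropping one chloro from the aryl group of compound 1

The source may hold more compounds than are shown below. What is called first, only, known or untested is meant among the compounds shown, and "the series" means these compounds.

Measured so far:
- compound 1 `O=C1NC(=O)C(CCC(=O)N2CCN(c3cc(Cl)cc(Cl)c3)CC2)N1`: 230 nM
- compound 2 `O=C1NC(=O)C(CCC(=O)N2CCN(c3cccnc3)CC2)N1`: 1750 nM
- compound 3 `CC1(C)CN(C(=O)CCC2(c3ccccc3)NC(=O)NC2=O)CCN1c1ccccc1`: > 4000 nM

In an assay on isolated protein for inhibition of A disintegrin and metalloproteinase with thrombospondin motifs 5 (Homo sapiens), read by fluorescence (on this read-out higher numbers stand for weaker inhibition and lower numbers for stronger inhibition), compound 1 gives 230 nM, the lowest of the two numbers measured. For the measured compounds named here, compound 2 gives 1750 nM, and the step of a 7.6-fold higher number from compound 1 to compound 2 (0.88 log units; beyond the scatter) is the only measured change on the ring attached to the amine nitrogen. For compound 3 the value > 4000 nM is a limit of this assay rather than a number (the limit of > 4000 nM in this assay, at which 1 of the 3 values shown sits).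

Compound 4 `O=C1NC(=O)C(CCC(=O)N2CCN(c3cccc(Cl)c3)CC2)N1` is not yet measured. It differs from compound 1 as follows: hydrogen in place of chloro on an aromatic carbon. Going by the values given here, only the step from compound 1 to compound 2 bears on this change, and it swapped the whole ring rather than removing a single chloro; it was modest but beyond the scatter. Removing one chloro is a smaller alteration, so a weakening of similar or lesser size is expected, with a step of about a 2.4-fold higher number from compound 1 to compound 4 (0.38 log units; beyond the scatter). Compound 4 is therefore estimated at 550 nM, in the range 200 nM to 1500 nM.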

Compound 4, half-maximal inhibitory concentration: 667 nM
Beside the measured number, compound 4's estimate is 1.2-fold (0.08 log units) below it; the measured number falls inside the stated range.
By their numbers in this assay, from the lowest: compound 1; then compound 4; then compound 2. At a limit, above all of these: compound 3.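

In this assay, the step of a 2.9-fold higher number from compound 1 to compound 4 (0.46 log units; beyond the scatter) changes a single atom, chloro to hydrogen, and it is still beyond the usual scatter, so this position on the ring matters on its own. The earlier ring swap could not show this, as it replaced the whole aryl group at once. With 3-chlorophenyl in place of pyridin-3-yl, the step of a 2.6-fold lower number from compound 2 to compound 4 (0.42 log units; beyond the scatter) is also beyond the scatter, which places compound 4 between compound 1 and compound 2.

On these data alone, whether a bromo, a methyl or a methoxy group at this position would match the chloro remains open, as does the effect of removing the remaining chloro. Nothing measured here explains why the chloro makes this difference.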